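The source may hold more compounds than are shown below. What is called first, only, known or untested is meant among the compounds shown, and "the series" means these compounds.

Measured so far in an assay for inhibition of serine/threonine-protein kinase PLK2 (Homo sapiens), read by FRET and Z'-LYTE, with a stated time of 1 h; on this read-out lower numbers stand for stronger inhibition and higher numbers for weaker inhibition:
compound 1, `CCC1C(=O)N(C)c2cnc(Nc3ccc(S(=O)(=O)NCC(C)C)cc3)nc2N1c1ccn(C)n1`, 311 nM
compound 2, `CCCNS(=O)(=O)c1ccc(Nc2ncc3c(n2)N(c2ccn(C)n2)C(CC)C(=O)N3C)cc1`, 190 nM

Within the data shown here, compound 2 stands lowest of the two numbers, and the only measured step, a 1.6-fold lower number from compound 1 to compound 2 (0.21 log units; within the scatter), lies within the scatter. Compound 3, `CCC1C(=O)N(C)c2cnc(Nc3ccc(S(N)(=O)=O)cc3)nc2N1c1ccn(C)n1`, differs from compound 2 by hydrogen in place of propyl on a sulfonamide nitrogen. Among the measured compounds shown here, the one step that bears on it, a 1.6-fold lower number from compound 1 to compound 2 (0.21 log units; within the scatter), shortened the same chain by one carbon and changed little; removing the whole chain goes further than anything measured. Compound 3 is therefore expected to show a step of a 1.7-fold higher number from compound 2 to compound 3 (0.23 log units; within the scatter), likely no further than the scatter. Compound 3 is estimated at 320 nM, with a range from 110 nM to 950 nM.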

Compound 3, half-maximal inhibitory concentration: 121 nM
Beside the measured number, compound 3's estimate is 2.6-fold (0.42 log units) above it; the measured number falls inside the stated range.
By their numbers in this assay, from the lowest: compounds 3, 2 and 1 (each within the scatter of the next, the first and the last beyond it).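

In this assay, among these compounds, the sulfonamide nitrogen keeps its activity with no alkyl chain at all: hydrogen in place of propyl gives a 1.6-fold lower number from compound 2 to compound 3 (0.20 log units; within the scatter) and hydrogen in place of isobutyl gives a 2.6-fold lower number from compound 1 to compound 3 (0.41 log units; beyond the scatter) as the one modest step beyond the scatter. Of the two chains, only the isobutyl of compound 1 stands apart from the bare sulfamoyl of compound 3. No evidence is at hand to explain this. On these data alone, what a methyl, a longer chain or a chain ending in an amine or a carboxylic acid would do on this nitrogen stays open.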